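From butyl to methoxy on a fused core

The source may hold more compounds than are shown below. What is called first, only, known or untested is meant among the compounds shown, and "the series" means these compounds.

compound 1 `Nc1ncnc2c1nc(O)n2C1CCCC1`: > 10 uM
compound 2 `Cc1nc(N)c2nc(O)n(Cc3ccccc3)c2n1`: 1 uM
compound 3 `CCCCc1nc(N)c2nc(O)n(Cc3ccccc3)c2n1`: 0.03 uM

In a functional assay (spleen, spleen) for activation, with Mus musculus as the target (on this read-out higher numbers stand for an effect only at larger amounts of compound and lower numbers for an effect already at smaller amounts), compound 3 gives 0.03 uM, the lowest of the two numbers shown; nearest stands compound 2 with 1 uM. For compound 1 the value > 10 uM is a limit of the assay rather than a number (the limit of > 10 uM in this assay, at which 1 of the 3 values shown sits). Compound 4 `COc1nc(N)c2nc(O)n(Cc3ccccc3)c2n1` differs from compound 3 by methoxy in place of butyl on an aromatic carbon. Going by the values given here, the one measured step at this position, a 33-fold lower number from compound 2 to compound 3 (1.52 log units; beyond the scatter), was large and shows how strongly the group there sets the read-out, but it involved no methoxy, so it guides the direction only roughly. The expected step is a 10-fold higher number from compound 3 to compound 4 (1.00 log units; beyond the scatter), toward a higher number. For compound 4 the estimate is 0.3 uM, within 0.03 uM to 3 uM.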

Compound 4, minimum effective concentration: 0.1 uM
Compound 4: middle estimate off by 3.0-fold (0.48 log units), on the high side; the measured number falls inside the stated range.
By their numbers in this assay, from the lowest: compound 3; then compound 4; then compound 2. At a limit, above all of these: compound 1.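

In this assay, methoxy on the aromatic carbon between two ring nitrogen atoms gives a 10-fold lower number from compound 2 to compound 4 (1.00 log units; beyond the scatter), yet it still falls short of butyl, with a 3.3-fold higher number from compound 3 to compound 4 (0.52 log units; beyond the scatter). Going by these compounds alone, a butyl chain is therefore not the only group at this position that brings the number well down from that of the methyl compound. Methoxy, the only one of these three groups with a hydrogen-bond acceptor, lands in the middle of the series, but nothing shown gives a reason for either step. As far as these compounds go, whether butoxy or an amine at this position would give a lower number than butyl stays open.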